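Pyridin-4-yl in Place of 2-Methoxyphenyl on the Shared Core

A few compounds are considered here, and "the series" means these few. Any claim that something is new, unique, unknown or untested is made for them only; others in the source may bear on it.

Of the compounds shown here, two have been measured in a functional assay on SGC-7901 cells (Homo sapiens) for cytotoxicity, read by MTT assay, with a stated time of 48 h; on this read-out higher numbers stand for weaker inhibition and lower numbers for stronger inhibition. Compound 1 `COc1ccccc1-c1nnc(SCCn2c([N+](=O)[O-])cnc2C)o1` gives 30500 nM and stands at the highest of the two numbers. Compound 2 `COc1cc(OC)cc(-c2nnc(SCCn3c([N+](=O)[O-])cnc3C)o2)c1` gives 9600 nM in this assay, a lower number than that of compound 1 and beyond the scatter, so compound 2 inhibits more strongly on this read-out.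

Compound 3 `Cc1ncc([N+](=O)[O-])n1CCSc1nnc(-c2ccncc2)o1` is not yet measured. It differs from compound 1 in one place: pyridin-4-yl in place of 2-methoxyphenyl on an aromatic carbon. Within the data shown here, no measured pair follows this exact change, so no step size can be read from the data, and the direction is open.

The step of a 1.4-fold lower number from compound 1 to compound 3 (0.14 log units; within the scatter) is expected to stay small, no further than the scatter allows, in either direction. For compound 3 the estimated value in this assay is 22000 nM, with a range from 7000 nM to 70000 nM.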

Compound 3, half-maximal inhibitory concentration: 15900 nM
For compound 3 the middle estimate is 1.4-fold (0.14 log units) above the measured one; measured number inside the range.
By their numbers in this assay, from the lowest: compounds 2, 3 and 1 (each within the scatter of the next, the first and the last beyond it).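

In this assay, pyridin-4-yl in place of 2-methoxyphenyl on the aromatic carbon of the five-membered ring gives a 1.9-fold lower number from compound 1 to compound 3 (0.28 log units; within the scatter), the first step read at this position. The position therefore tolerates this exchange of a carbon-only aromatic ring for one with a ring nitrogen, with the read-out staying within the scatter, although the group entering has fewer heavy atoms than the one leaving. Nothing available explains this result.

This single step cannot separate the loss of the methoxy group from the entry of the ring nitrogen, and a plain phenyl group at this position would be needed to tell the two apart. Also open, from the compounds shown here alone, is whether pyridin-3-yl or a saturated ring amine such as piperidin-4-yl would stay as close to compound 1.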